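Cutting the side chain back to an allyl ether

This account rests on a few compounds, and the source may have more. Where it says the series, first, only, none or still open, it means among the compounds named here.

In a toxicity assay on the whole organism (J774 cells) for cytotoxicity, with Mus musculus as the target, read by MTT assay, with a stated time of 24 h, tested at 10 uM (on this read-out higher numbers stand for a weaker effect at the one concentration tested and lower numbers for a stronger effect), compound 3 `CCCCCCCCCO[C@@H]1[C@@H](N)[C@@H](OCC(O)CNCCCN)O[C@H](CN)[C@H]1OCCCCCCCCC` gives 101%. Compound 2 `CCCCCCCCCO[C@@H]1[C@@H](N)[C@@H](OCC(O)CNCCO)O[C@H](CN)[C@H]1OCCCCCCCCC` gives 99.1%, which sits within the scatter of that, while compound 1 `CCCCCCCCCO[C@@H]1[C@@H](N)[C@@H](OCC(O)CO)O[C@H](CN)[C@H]1OCCCCCCCCC` gives 89.7%, a gap that lies beyond the scatter. The steps measured so far all build onto the same side chain: a number 9.4 percentage points higher from compound 1 to compound 2 (within the scatter), a number 11.3 percentage points higher from compound 1 to compound 3 (beyond the scatter), and a number 1.9 percentage points higher from compound 2 to compound 3 (within the scatter). Compound 4 `C=CCO[C@H]1O[C@H](CN)[C@@H](OCCCCCCCCC)[C@H](OCCCCCCCCC)[C@H]1N` goes the other way and strips that chain down: vinyl in place of 2-((3-aminopropyl)amino)-1-hydroxyethyl on a saturated chain carbon bound to an oxygen on a saturated carbon. The step from compound 1 to compound 3, read backwards, bears most directly on this change, and it points to the number coming back down by a modest amount once the (3-aminopropyl)amino part is gone. The loss of the hydroxy as well has no measured counterpart among these compounds, so nothing further is assumed for it. A modest drop toward the value of compound 1 is therefore expected, a number 13 percentage points lower from compound 3 to compound 4 (beyond the scatter). Compound 4 is estimated at 88%, with a range from 70% to 101%.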

Compound 4, a percentage reported as activity, at one concentration (the size of the read-out at that concentration, not a potency): 91.4%
Beside the measured number, compound 4's estimate is 3.4 percentage points below it; the measured number falls inside the stated range.
By their numbers in this assay, from the lowest: compounds 1, 4, 2 and 3 (each within the scatter of the next, the first and the last beyond it).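

In this assay, among the compounds shown here, cutting the side chain back to allyl gives no step that stands clear of the scatter: a number 9.6 percentage points lower from compound 3 to compound 4 (within the scatter) and a number 7.7 percentage points lower from compound 2 to compound 4 (within the scatter) and a number 1.7 percentage points higher from compound 1 to compound 4 (within the scatter). At this position, then, 3-((3-aminopropyl)amino)-2-hydroxypropyl can give way to allyl with no reading that can be told apart from the earlier compounds, so neither the amines nor the hydroxy groups of these side chains are shown to be needed for this result. Compound 4 also lies within the scatter of both compound 1 and compound 3, although those two lie beyond the scatter of each other, and no measurement at hand offers a reason for any of this.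

Still open, on these data alone, is how a carboxylic acid or a guanidine on this side chain would read. Also open, as far as these compounds go, is how a much longer chain in place of allyl would read.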